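A few compounds are considered here, and "the series" means these few. Any claim that something is new, unique, unknown or untested is made for them only; others in the source may bear on it.

Measured in a functional assay on the whole organism (strain Kunming) with Mus musculus as the target, with a stated time of 0.5 h; on this read-out higher numbers stand for an effect only at larger amounts of compound and lower numbers for an effect already at smaller amounts:
Compound 1 `COc1cc(OC)c(OC)cc1/C=C/COC(=O)/C=C/c1c(OC)ccc(OC)c1OC`: 212 mg/kg
Compound 2 `COc1cc(OC)c(OC)cc1/C=C/COC(=O)/C=C/c1ccccc1C(F)(F)F`: > 200 mg/kg (a limit)
Compound 3 `COc1cc(OC)c(OC)cc1/C=C/COC(=O)/C=C/c1cc(OC)c(OC)c(OC)c1`: 204 mg/kg

The account follows the step from compound 2 to compound 4 `COc1cc(OC)c(OC)cc1/C=C/COC(=O)/C=C/c1ccc(Cl)cc1`. Compound 2 has no number on this read-out. Its entry of > 200 mg/kg is a limit of the assay. Compound 1 at 212 mg/kg and compound 3 at 204 mg/kg lie within the scatter of each other.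

The change is 4-chlorophenyl in place of 2-(trifluoromethyl)phenyl on a double-bonded chain carbon bound to a double-bonded chain carbon. In words, 4-chlorophenyl takes the place of 2-(trifluoromethyl)phenyl on a double-bonded chain carbon bound to a double-bonded chain carbon.

Going by the values given here, no measured pair in this assay differs in one place only, so nothing gives this change a size or a direction. The expectation rests on compound 1 at 212 mg/kg and compound 3 at 204 mg/kg, which carry other groups at this place and still give values within the scatter of each other. The expected step is an at least 1.0-fold lower number from compound 2 to compound 4 (0.02 log units; that floor lies within the scatter), none beyond the scatter. Compound 4 is estimated at 190 mg/kg, with an expected range from 100 mg/kg to 300 mg/kg.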

Compound 4, dose for half-maximal effect: 142 mg/kg
The estimate for compound 4 lay 1.3-fold (0.13 log units) above the measured number, and the stated range covers the measured number.
By their numbers in this assay, from the lowest: compounds 4, 3 and 1 (each within the scatter of the next).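

In this assay, 4-chlorophenyl in place of 2-(trifluoromethyl)phenyl on a double-bonded chain carbon bound to a double-bonded chain carbon gives an at least 1.4-fold lower number from compound 2 to compound 4 (0.14 log units; that floor lies within the scatter). This is the only pair shown that differs in one place, so this change now has a direction and a floor, though that floor does not clear the usual scatter. Compound 2 carries a limit and not a number, so the full size of the step cannot be read: the limit of > 200 mg/kg in this assay, at which 1 of the 4 values shown sits.

The step replaces the whole group, so it does not show whether the chlorine or the loss of the trifluoromethyl goes with the lower number. It also leaves open how the number would move with an amine or a carboxylic acid on the phenyl ring at this place, or with a longer chain in place of the ring.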